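Sulfonyl swap: morpholin-4-yl in place of 1-methylpiperidin-4-yl

The source may report more compounds than this note shows. Statements on the series, on what has been measured and on what is new or still open speak of the compounds shown alone.

In a functional assay on A2780 cells (Homo sapiens) for cytotoxicity, read by sulforhodamine B assay, with a stated time of 72 h (on this read-out lower numbers stand for stronger inhibition and higher numbers for weaker inhibition), compound 1 `O=C(NCc1ccc(S(=O)(=O)C2CCC(F)(F)CC2)cc1)N1Cc2ccncc2C1` gives 13 nM. Going by the values given here, compound 2 `CN1CCC(S(=O)(=O)c2ccc(CNC(=O)N3Cc4ccncc4C3)cc2)CC1` gives 99 nM, the higher of the two numbers so far, which puts it at the weak end of this small set.

Compound 3 `O=C(NCc1ccc(S(=O)(=O)N2CCOCC2)cc1)N1Cc2ccncc2C1` has no number yet. It carries morpholin-4-yl in place of 1-methylpiperidin-4-yl on a sulfonyl sulfur.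

Among the compounds with values here, only one measured step bears on this place: a 7.6-fold higher number from compound 1 to compound 2 (0.88 log units; beyond the scatter), with 1-methylpiperidin-4-yl in place of 4,4-difluorocyclohexyl on a sulfonyl sulfur. That step shows that the group at this place can shift the number in this assay well beyond the scatter. Within the data shown here, no measured compound carries morpholin-4-yl, so the direction rests on little. Compound 2 sits at the high end, and compound 1 shows that a lower number is reachable at 13 nM.

The expected step, smaller than the measured one and toward a lower number, is a 2.5-fold lower number from compound 2 to compound 3 (0.39 log units; beyond the scatter). The estimate for compound 3 is 40 nM, with an expected range of 10 nM to 150 nM.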

Compound 3, half-maximal inhibitory concentration: 68 nM
Estimate against measurement, compound 3: 1.7-fold (0.23 log units) below, and the stated range covers the measured number.
By their numbers in this assay, from the lowest: compound 1; then compounds 3 and 2 (each within the scatter of the next).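

In this assay, the step of a 1.5-fold lower number from compound 2 to compound 3 (0.16 log units; within the scatter) shows that this change on a sulfonyl sulfur leaves the number within the scatter, although morpholin-4-yl brings a ring oxygen and 1-methylpiperidin-4-yl a ring nitrogen carrying a methyl group. The step of a 5.2-fold higher number from compound 1 to compound 3 (0.72 log units; beyond the scatter) adds a second comparison with 4,4-difluorocyclohexyl beyond the scatter, so among these three compounds the separation lies between compound 1 on one side and compound 2 and compound 3 on the other, not between the two groups containing ring hetero atoms. No accompanying measurement bears on why these numbers fall as they do.

The compounds shown leave open whether the separation of compound 1 follows the two fluorine atoms or the absence of a ring hetero atom, as 4,4-difluorocyclohexyl differs from the other two groups in both respects. A plain cyclohexyl on the same sulfonyl sulfur would separate these two readings, and a piperidin-1-yl would show whether the ring oxygen of morpholin-4-yl matters to the number at all.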